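This account rests on a few compounds, and the source may have more. Where it says the series, first, only, none or still open, it means among the compounds named here.

Compound 2, `CC(C)c1c(C(=O)N2CCCC2c2ccccc2)nn(-c2ccc(F)cc2)c1OC[C@@H](O)C[C@@H](O)CC(=O)O`, stands at the high end of the three measured numbers: in a functional assay on L6 cells (Rattus norvegicus) for inhibition (on this read-out higher numbers stand for weaker inhibition and lower numbers for stronger inhibition), compound 2 gives 4340 nM, the weakest inhibition shown. Compound 1, `CC(C)c1c(C(=O)N(C)Cc2cccc(F)c2)nn(-c2ccc(F)cc2)c1CC[C@@H](O)C[C@@H](O)CC(=O)O`, comes nearest to it, and in this assay compound 1 gives 1900 nM. Compound 3, `Cc1cccc(CNC(=O)c2nn(-c3ccc(F)cc3)c(OC[C@@H](O)C[C@@H](O)CC(=O)O)c2C(C)C)c1`, is the furthest away; in this assay compound 3 gives 280 nM.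

Compound 4, `CC(C)c1c(C(=O)NCc2ccccc2Cl)nn(-c2ccc(F)cc2)c1OC[C@@H](O)C[C@@H](O)CC(=O)O`, differs from compound 2 in one place on the shared core: (2-chlorobenzyl)amino in place of 2-phenylpyrrolidin-1-yl on a carbonyl carbon. Within the data shown here, the one measured step that bears on this change is the one from compound 2 to compound 3, where a (3-methylbenzyl)amino group replaced the same 2-phenylpyrrolidin-1-yl on the carbonyl carbon and gave a 16-fold lower number from compound 2 to compound 3 (1.19 log units; beyond the scatter). Compound 4 carries a (2-chlorobenzyl)amino group at that carbonyl carbon, so its change is of the same kind, with a different substituent on the benzyl ring. A drop of comparable size, toward stronger inhibition, is therefore expected for compound 4 in this assay, and the step from compound 2 to compound 4 is estimated as an 11-fold lower number from compound 2 to compound 4 (1.04 log units; beyond the scatter). For compound 4 the expected value in this assay is 400 nM, with a range from 150 nM to 1200 nM.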

Compound 4, half-maximal inhibitory concentration: 8450 nM
Estimate against measurement, compound 4: 21-fold (1.32 log units) below, outside the stated range (above it).
By their numbers in this assay, from the lowest: compound 3; then compound 1; then compounds 2 and 4 (each within the scatter of the next).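

In this assay, the (2-chlorobenzyl)amino group does not repeat what the (3-methylbenzyl)amino group did on the same carbonyl carbon: a 1.9-fold higher number from compound 2 to compound 4 (0.29 log units; within the scatter) lies within the scatter, so compound 2 and compound 4 cannot be told apart here, although compound 4 has lost the 2-phenylpyrrolidin-1-yl group and gained the amide hydrogen, as compound 3 did. Among these compounds, replacing 2-phenylpyrrolidin-1-yl with a benzylamino-type group therefore does not by itself bring stronger inhibition, and the outcome at this position depends on what the benzyl ring carries, since a 30-fold higher number from compound 3 to compound 4 (1.48 log units; beyond the scatter) is a large step that changes only that ring's substituent, 2-chlorophenyl in place of 3-methylphenyl. Nothing given here accounts for this difference between the two rings.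

Compound 3 and compound 4 differ in both the kind of substituent and its place on the ring, so the two contributions cannot be separated. Going by these compounds, an unsubstituted benzylamino group or a (2-methylbenzyl)amino group on this carbonyl carbon could start to separate them, and how either would read in this assay remains open.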